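A few compounds are considered here, and "the series" means these few. Any claim that something is new, unique, unknown or untested is made for them only; others in the source may bear on it.

Compound 1: `COc1ccccc1N1CCN(CCCNc2ncccc2C(=O)N(C)C)CC1` gives 1.59 nM in a functional assay for antagonist activity at Alpha-1A adrenergic receptor (Oryctolagus cuniculus); a higher number here means weaker binding, a lower number tighter binding.
Compound 2: `CN(C)C(=O)c1cccnc1NCCCN1CCN(c2ccccc2O)CC1` gives 5.01 nM in this assay.
Compound 3: `CCOc1ccccc1N1CCN(CCCNc2ncccc2C(=O)N(C)C)CC1` is not yet measured in this assay.

Among the two measured compounds, compound 2 stands at the higher number in this assay, with compound 1 as its only neighbour at a lower one. The step from compound 2 to compound 3 is ethyl in place of hydrogen on an oxygen on an aromatic ring; described one bond further out, it is hydroxy to ethoxy, or 2-hydroxyphenyl to 2-ethoxyphenyl. Within the data shown here, the one measured step that bears on this change runs the other way on the same oxygen: a 3.2-fold higher number from compound 1 to compound 2 (0.50 log units; beyond the scatter), where hydrogen replaced methyl. Among the measured compounds shown here, since compound 3 carries an alkyl group on that oxygen again, as compound 1 does, the expectation is a step back down toward the number of compound 1, though an ethyl is not a methyl, and no measured pair shows how the longer group behaves here, so the expected change is a 2.0-fold lower number from compound 2 to compound 3 (0.30 log units; within the scatter) with some uncertainty. The estimate for compound 3 in this assay is therefore 2.5 nM, with a plausible range from 1 nM to 7 nM.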

Compound 3, dissociation constant: 0.501 nM
Estimate against measurement, compound 3: 5.0-fold (0.70 log units) above; measured number outside the range, below it.
By their numbers in this assay, from the lowest: compound 3; then compound 1; then compound 2.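

In this assay, putting ethyl on the oxygen of compound 2 gives a 10-fold lower number from compound 2 to compound 3 (1.00 log units; beyond the scatter), so this step does more than return the number to that of compound 1, the methyl ether. The step of a 3.2-fold lower number from compound 1 to compound 3 (0.50 log units; beyond the scatter) shows that the size of the alkyl group on this oxygen matters, and that the identity of the group counts as well as whether the hydrogen is replaced. Across these three compounds, the number falls in order from hydroxy through methoxy to ethoxy, with each step beyond the scatter, but nothing measured here offers an explanation for that order.

The compounds shown leave open whether the number would keep falling with a longer chain on the oxygen, such as propyl or butyl, or whether it would turn back up. They also cannot say how a branched group such as isopropyl, or a chain ending in an amine or a carboxylic acid, would behave at this position.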